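Chain Extension Toward a Longer Linker at the Cyclohexyl Core

The source may report more compounds than this note shows. Statements on the series, on what has been measured and on what is new or still open speak of the compounds shown alone.

Compound 1 `c1ccc(CC[C@H]2CCCC[C@@H]2NC2=NCCO2)cc1` is the reference point. Going by the values given here, in an assay on cells for inhibition of Alpha-2C adrenergic receptor (Homo sapiens) (a higher number here means a weaker inhibitor, a lower number a stronger inhibitor), compound 1 gives 10.7 nM, the lowest of the three numbers known here. Compound 2 `c1ccc(CCC[C@H]2C3CCC(C3)[C@H]2NC2=NCCO2)cc1` gives 123 nM, and compound 3 `CCC[C@H]1C2CCC(C2)[C@H]1NC1=NCCO1` gives 123 nM, both beyond the scatter above compound 1.

Compound 4 `c1ccc(CCC[C@H]2CCCC[C@@H]2NC2=NCCO2)cc1` differs from compound 1 by benzyl in place of phenyl on a saturated chain carbon, two bonds along the chain from a saturated ring carbon, so the linker to the aromatic ring grows by one carbon.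

Among the compounds with values here, no measured step changes a chain length on this core, so the expectation rests on an indirect clue. Within the data shown here, the only step with the longer chain, no change at the digits printed from compound 2 to compound 3 (within the scatter), shows that on a different core the phenyl three bonds out can be removed without effect, which suggests that an aromatic ring at that distance adds little. The shorter chain of compound 1, by contrast, goes with the lowest number seen. The step from compound 1 to compound 4 is therefore expected to be a moderate loss, a 3.3-fold higher number from compound 1 to compound 4 (0.51 log units; beyond the scatter), though the absence of a direct comparison leaves the range wide.

Compound 4 is expected to give about 35 nM in this assay, within roughly 9 nM to 130 nM.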

Compound 4, inhibition constant: 32.4 nM
Compound 4: middle estimate off by 1.1-fold (0.03 log units), on the high side; low and high end bracket the measured number.
By their numbers in this assay, from the lowest: compound 1; then compound 4; then compounds 2 and 3 (each within the scatter of the next).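

Going by these compounds alone, on the core of compound 1, this is the first direct reading of chain length in this assay: benzyl in place of phenyl on a saturated chain carbon, two bonds along the chain from a saturated ring carbon, gives a 3.0-fold higher number from compound 1 to compound 4 (0.48 log units; beyond the scatter) and lies beyond the scatter, though the step is modest. Within the data shown here, the only earlier step, no change at the digits printed from compound 2 to compound 3 (within the scatter) on another core, was a removal of phenyl and showed no change beyond the scatter, whereas this step shows that on the core of compound 1 the number does respond to a change at this chain position with the aromatic ring kept in place. No supporting measurement bears on why the number rises with benzyl, so the step stands as an observation only.

The compounds shown leave open whether a still longer chain at this place would raise the number further, or whether the step would hold with a pyridine ring in place of the phenyl ring. They also leave open what hydrogen in place of the aromatic group would do on the core of compound 1, where only the chain-bearing compounds are seen.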